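Moving the Trifluoromethoxy Group Around the Benzoyl Ring

This account rests on a few compounds, and the source may have more. Where it says the series, first, only, none or still open, it means among the compounds named here.

Compound 1 `O=C(c1ccc(OC(F)(F)F)cc1)N1CCC(N(C2CC2)S(=O)(=O)c2cccc(C(F)(F)F)c2)CC1` is the starting point of this step. Within the data shown here, in an assay on HEK293 cells for inhibition of Voltage-dependent N-type calcium channel subunit alpha-1B (Homo sapiens), read by FLIPR and calcium flux, in the presence of a further agent that is not named here (on this read-out lower numbers stand for stronger inhibition and higher numbers for weaker inhibition), compound 1 gives 300 nM, the second highest of the three numbers measured so far. Two close relatives are known. Compound 2 `CS(=O)(=O)c1ccccc1C(=O)N1CCC(N(C2CC2)S(=O)(=O)c2cccc(C(F)(F)F)c2)CC1` gives 660 nM in this assay, and compound 3 `O=C(c1ccccc1OC(F)(F)F)N1CCC(N(C2CC2)S(=O)(=O)c2cccc(C(F)(F)F)c2)CC1` gives 120 nM. The measured steps are a 2.2-fold higher number from compound 1 to compound 2 (0.34 log units; beyond the scatter), a 2.5-fold lower number from compound 1 to compound 3 (0.40 log units; beyond the scatter) and a 5.5-fold lower number from compound 2 to compound 3 (0.74 log units; beyond the scatter), all modest but beyond the scatter.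

Compound 4 `O=C(c1cccc(OC(F)(F)F)c1)N1CCC(N(C2CC2)S(=O)(=O)c2cccc(C(F)(F)F)c2)CC1` has not yet been measured in this assay. It differs from compound 1 in one place: 3-(trifluoromethoxy)phenyl in place of 4-(trifluoromethoxy)phenyl on a carbonyl carbon. Among the measured compounds shown here, the only measured step that also moves the trifluoromethoxy group on this ring is a 2.5-fold lower number from compound 1 to compound 3 (0.40 log units; beyond the scatter), a modest lowering. For the measured compounds named here, no measured step covers the 3-(trifluoromethoxy)phenyl itself, so the direction for compound 4 is read from that single comparison with caution. A modest lowering of the number, or none beyond the scatter, is therefore expected. Compound 4 is estimated to give 200 nM in this assay, within a range from 80 nM to 500 nM. This estimate corresponds to an expected step of a 1.5-fold lower number from compound 1 to compound 4 (0.18 log units; within the scatter).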

Compound 4, half-maximal inhibitory concentration: 370 nM
Compound 4: middle estimate off by 1.9-fold (0.27 log units), on the low side; measured number inside the range.
By their numbers in this assay, from the lowest: compound 3; then compounds 1, 4 and 2 (each within the scatter of the next, the first and the last beyond it).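

In this assay, 3-(trifluoromethoxy)phenyl and 4-(trifluoromethoxy)phenyl on the carbonyl carbon are not told apart, with a 1.2-fold higher number from compound 1 to compound 4 (0.09 log units; within the scatter) lying within the scatter, so the earlier gain with 2-(trifluoromethoxy)phenyl is not part of a steady trend around the ring. Instead, 2-(trifluoromethoxy)phenyl stands apart from both other placements, as a 3.1-fold higher number from compound 3 to compound 4 (0.49 log units; beyond the scatter) and a 2.5-fold lower number from compound 1 to compound 3 (0.40 log units; beyond the scatter) are both beyond the scatter, while a 1.8-fold lower number from compound 2 to compound 4 (0.25 log units; within the scatter) leaves 3-(trifluoromethoxy)phenyl unseparated from the 2-(methylsulfonyl)phenyl of the earlier series. Nothing given here explains why the 2-(trifluoromethoxy)phenyl placement stands apart.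

The compounds shown leave open whether the separation belongs to the trifluoromethoxy group itself or would also appear with another group on the ring, such as a methoxy group, a chlorine atom or a nitrile in the same placement. They also leave open whether 3-(methylsulfonyl)phenyl or 4-(methylsulfonyl)phenyl would follow the order seen for the three trifluoromethoxy placements, and whether that order would hold if an amine or a carboxylic acid were carried on the benzoyl ring.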